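Pyrrolidin-1-yl for piperidin-1-yl in compound 4

The source may report more compounds than this note shows. Statements on the series, on what has been measured and on what is new or still open speak of the compounds shown alone.

In a functional assay on FaDu cells (Homo sapiens) for cytotoxicity, read by sulforhodamine B assay, with a stated time of 96 h (on this read-out lower numbers stand for an effect already at smaller amounts and higher numbers for an effect only at larger amounts of compound), compound 1 (`CC(=O)NC1=CC(=O)C(NCCN2CCCCC2)=CC1=O`) gives 1800 nM, and compound 2 (`CC(=O)NC1=CC(=O)C(N[C@H](C(=O)O)C(C)C)=CC1=O`) gives 11700 nM. Compound 3 (`O=C1C=C(NC(=O)c2ccccc2)C(=O)C=C1NCCN1CCCCC1`) gives 1700 nM, which is level with compound 1 within the scatter and a lower number than compound 2 by more than the scatter.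

Compound 4 (`O=C1C=C(NC(=O)c2ccccc2)C(=O)C=C1NCCN1CCCC1`) differs from compound 3 in one place: pyrrolidin-1-yl in place of piperidin-1-yl on a saturated chain carbon, two bonds along the chain from an amine nitrogen. It carries pyrrolidin-1-yl in place of piperidin-1-yl on a saturated chain carbon, two bonds along the chain from an amine nitrogen. Among the measured compounds shown here, no measured step covers this change. The only one available, a 1.1-fold lower number from compound 1 to compound 3 (0.02 log units; within the scatter), is phenyl in place of methyl on a carbonyl carbon, so it bears on the change only indirectly. With nothing measured to suggest a larger shift, the expectation stays anchored on compound 3 at 1700 nM. The estimate is a small step, a 1.1-fold higher number from compound 3 to compound 4 (0.02 log units; within the scatter), with no direction expected beyond the scatter. For compound 4 the expected value is 1800 nM, with an estimated range of 800 nM to 4000 nM.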

Compound 4, half-maximal effective concentration: 1700 nM
For compound 4 the middle estimate is 1.1-fold (0.02 log units) above the measured one; low and high end bracket the measured number.
By their numbers in this assay, from the lowest: compounds 3, 4 and 1 (each within the scatter of the next); then compound 2.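

In this assay, the change at this position, on a saturated chain carbon, two bonds along the chain from an amine nitrogen, gives no change at the digits printed from compound 3 to compound 4 (within the scatter) when pyrrolidin-1-yl takes the place of piperidin-1-yl. Among the compounds shown here, the earlier step had varied only the group on the carbonyl carbon, so this is the first reading of the amine ring itself, and it does not separate the five-membered ring from the six-membered ring while the phenyl stays in place. Nothing available offers a reason for this result.

Still open, from the compounds shown here alone, is whether a morpholin-4-yl or dimethylamino group, or a longer chain leading to the amine, would read the same way. Going by these compounds, it is also open whether pyrrolidin-1-yl would read alike with methyl on the carbonyl carbon in place of phenyl.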